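The source may hold more compounds than are shown below. What is called first, only, known or untested is meant among the compounds shown, and "the series" means these compounds.

Measured so far in a functional assay on HT-29 cells (Homo sapiens) for antiproliferative activity, read by MTT assay, with a stated time of 96 h (on this read-out lower numbers stand for stronger inhibition and higher numbers for weaker inhibition), are three compounds:

- compound 1 `O=C1NNC(=O)C2(CSC3=C2C(=O)c2ncccc2C3=O)N1` gives 1580 nM; 1600 nM; 1600 nM (3 entries)
- compound 2 `CCCCCc1ccc(N2C(=O)NC3(CSC4=C3C(=O)c3ncccc3C4=O)C2=O)cc1` gives 250 nM
- compound 3 `O=C1NN(c2ccc(Cl)cc2)C(=O)C2(CSC3=C2C(=O)c2ncccc2C3=O)N1` gives 220 nM

Repeat readings of compound 1 agree closely (the several entries of compound 1 in this assay, 1580 nM; 1600 nM; 1600 nM (3 entries)). Compound 3 at 220 nM and compound 2 at 250 nM sit within the scatter of each other. Both numbers are well under those of compound 1, which lacks the substituted phenyl group that the other two carry.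

Compound 4 (`Cc1ccc(N2NC(=O)NC3(CSC4=C3C(=O)c3ncccc3C4=O)C2=O)cc1`) keeps the core of compound 3 and has methyl in place of chloro on an aromatic carbon, para to a large group, a change from 4-chlorophenyl to 4-methylphenyl (methyl in place of chloro on an aromatic carbon). Among the measured compounds shown here, no measured pair shows this exchange, so only a small step is expected in this assay, with no firm direction and nothing beyond the scatter. The expectation rests on compound 3 (220 nM), whose phenyl group stays in place. The expected move is small (a 1.3-fold higher number from compound 3 to compound 4 (0.10 log units; within the scatter)). For compound 4 the estimated value is 280 nM as a middle figure, with an expected range (110 nM to 700 nM).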

Compound 4, half-maximal inhibitory concentration: 200 nM
Beside the measured number, compound 4's estimate is 1.4-fold (0.15 log units) above it; the range from low to high includes it.
By their numbers in this assay, from the lowest: compounds 4, 3 and 2 (each within the scatter of the next).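

Methyl in place of chloro on an aromatic carbon, para to a large group, gives a 1.1-fold lower number from compound 3 to compound 4 (0.04 log units; within the scatter) in this assay. Among the compounds shown here, this is the first measured pair for this exchange, and it shows that these two groups cannot be told apart at this position on this read-out, although the finding covers only these two groups. Compound 3 and compound 4 each rest on a single reading, while the one compound with repeat readings shows how closely this assay can reproduce a number: the several entries of compound 1 in this assay, 1580 nM; 1600 nM; 1600 nM (3 entries)

From the compounds shown here alone, whether a different group at the same place, such as an amine or a carboxylic acid, would move the number beyond the scatter remains open. Also open, going by these compounds, is whether the same exchange would read alike on the core of compound 2, which differs from that of compound 3.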